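An added amino group on a weakly antiproliferative compound

The source may hold more compounds than are shown below. What is called first, only, known or untested is meant among the compounds shown, and "the series" means these compounds.

Compound 1 `CC(Nc1ncnc2ccc(-c3cnn(C4CCNCC4)c3)cc12)c1c(Cl)ccc(F)c1Cl`: 7000 nM
Compound 2 `COc1cccc(CNc2ncnc3ccc(-c4cnn(C)c4)cc23)c1`: 48900 nM

In a functional assay on A549 cells (Homo sapiens) for antiproliferative activity, read by MTT assay, with a stated time of 72 h (on this read-out lower numbers stand for stronger inhibition and higher numbers for weaker inhibition), compound 1 gives 7000 nM, the lower of the two numbers, while compound 2 reaches 48900 nM. Compound 3 `CC(Nc1nc(N)nc2ccc(-c3cnn(C4CCNCC4)c3)cc12)c1c(Cl)ccc(F)c1Cl` keeps the core of compound 1 but has amino in place of hydrogen on an aromatic carbon, between two ring nitrogen atoms (amino in place of hydrogen on an aromatic carbon). For the measured compounds named here, no measured pair shows this change, so the expectation is uncertain. The estimated step is a 1.8-fold lower number from compound 1 to compound 3 (0.24 log units; within the scatter), small, towards a lower number and hardly beyond the scatter. For compound 3, the expected value is 4000 nM, with an estimated range of 1000 nM to 15000 nM.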

Compound 3, half-maximal inhibitory concentration: 8800 nM
Compound 3: the middle estimate sits 2.2-fold (0.34 log units) below what was measured, and the stated range covers the measured number.
By their numbers in this assay, from the lowest: compounds 1 and 3 (each within the scatter of the next); then compound 2.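

In this assay the swap of hydrogen for amino on an aromatic carbon, between two ring nitrogen atoms, amounts to a 1.3-fold higher number from compound 1 to compound 3 (0.10 log units; within the scatter) and so makes no change beyond the scatter. For the compounds shown here, this position on the core of compound 1 therefore carries an amino group without a measurable shift in the read-out, something the earlier compounds could not show. Nothing available explains this outcome. Still open, as far as these compounds go, is whether a methylamino group, a hydroxyl or a methyl at this position would move the number, and whether amino would behave alike with the side groups of compound 2.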